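The source may report more compounds than this note shows. Statements on the series, on what has been measured and on what is new or still open speak of the compounds shown alone.

Measured compounds:
- compound 1, `CCOC(=O)/C(C#N)=C/c1ccc(O)c(O)c1`: 57.8%
- compound 2, `NC/C(=C\c1ccc(O)c(O)c1)C(=O)O`: 50.1%

Both compounds share a core carrying two hydroxyl groups on an aromatic ring and a double-bonded chain carbon, and both were tested in a functional assay on the whole organism (strain CD1) for inhibition, with Mus musculus as the target, with stated times of 15 min and 20 min, at a dose of 10 mg/kg by the subcutaneous route; on this read-out lower numbers stand for less inhibition and higher numbers for more inhibition at the one dose given (going by the name of the read-out). In this assay compound 1 gives 57.8%, and compound 2 gives 50.1%. The gap between these two numbers lies within the usual scatter of repeated measurements, so the data do not separate them; compound 1 simply holds one of two numbers that sit close together.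

The next compound, compound 3, `N#C/C(=C\c1ccc(O)c(O)c1)C(=O)N1CCOCC1`, has not yet been measured. It differs from compound 1 in one place: morpholin-4-yl in place of ethoxy on a carbonyl carbon. The nitrile and the core are kept; only the group attached to the carbonyl carbon changes.

Going by the values given here, no pair of measured compounds shows the effect of such a change, so nothing in the data says whether the step will be large. The expectation for the step from compound 1 to compound 3 is therefore none beyond the scatter, a number 7.8 percentage points lower from compound 1 to compound 3 (within the scatter). Compound 3 is expected to give about 50% in this assay, with a range from 30% to 70%.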

Compound 3, a percentage reported as inhibition, in the whole organism at one dose (the size of the read-out at that dose, not a potency): 40%
Beside the measured number, compound 3's estimate is 10 percentage points above it, and the stated range covers the measured number.
By their numbers in this assay, from the lowest: compound 3; then compounds 2 and 1 (each within the scatter of the next).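

Swapping ethoxy for morpholin-4-yl on a carbonyl carbon gives a number 17.8 percentage points lower from compound 1 to compound 3 (beyond the scatter) in this assay, so with the nitrile and the shared core kept, the group at this place can change the size of the inhibition at the one dose given. Going by these compounds alone, this is the first measured step at this position, and it points downward for this particular swap. The two groups have the same counts of hydrogen-bond donors and acceptors and neither carries a net charge, so those counts do not distinguish them, and nothing measured here explains the fall.

The step changes two things at once: morpholin-4-yl brings in a six-membered non-aromatic ring and puts a nitrogen where ethoxy has an oxygen on the carbonyl carbon, and the compounds shown cannot separate these two changes. An open-chain diethylamino group at the same place would keep the nitrogen without the ring, while a longer chain such as butoxy or a free carboxylic acid would show how much room this position has for other groups.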